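Fluoro for bromo on the shared core: compound 3 to compound 4

The source may report more compounds than this note shows. Statements on the series, on what has been measured and on what is new or still open speak of the compounds shown alone.

Compound 1 `CCn1c(/C=C2/C(=O)Nc3ccccc32)nc2ccccc21` and compound 2 `CCn1c(/C=C2/C(=O)Nc3ccc(Br)cc32)nc2ccccc21` carry no result in a functional assay on MCF7 cells (Homo sapiens) for cytotoxicity, read by MTT assay, with a stated time of 48 h; a lower number here means a stronger inhibitor, a higher number a weaker inhibitor: compound 1 stands at "not determined" (no result reported) and compound 2 at "not determined" (no result reported). For the measured compounds named here, compound 3 `Cn1c(/C=C2/C(=O)Nc3ccc(Br)cc32)nc2ccccc21` is the only member with a reading, and that reading is a limit of the assay, > 50000 nM. Compound 3 therefore stands at the weak end of what this assay reports, with no single number; it is the point at which (the limit of > 50000 nM in this assay, at which 1 of the 3 values shown sits). Compound 4 `Cn1c(/C=C2/C(=O)Nc3ccc(F)cc32)nc2ccccc21` differs from compound 3 by fluoro in place of bromo on an aromatic carbon. Going by the values given here, with no measured step, any movement from compound 3 to compound 4 in this assay is expected to stay within the scatter, and the assay is expected again to return only a limit. Compound 4 is estimated at 70000 nM, expected between 20000 nM and 250000 nM, a step that the limit leaves unreadable from compound 3 to compound 4.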

Compound 4, half-maximal inhibitory concentration: 31600 nM
For compound 4 the middle estimate is 2.2-fold (0.35 log units) above the measured one; the range from low to high includes it.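

In this assay, for the compounds shown here, compound 4 is the only member of the series with a single number, so the position on the aromatic carbon now has a reading rather than only a limit. Fluoro in place of bromo gives an at least 1.5-fold lower number from compound 3 to compound 4 (0.19 log units; that floor lies within the scatter). Compound 3 remains a limit of the assay: the limit of > 50000 nM in this assay, at which 1 of the 4 values shown sits.

Open, as far as these compounds go, is whether an amine, a methoxy group or a carboxylic acid at this position would move the number beyond the scatter. Also open, from the compounds shown here alone, is what a propyl chain in place of the methyl on the shared core would do.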